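Cytotoxicity of Three Aryl Ketones on a Shared Core

The compounds below may be only part of what the source reports. "The series", "measured", "known", "first", "only" and "open" are said of these compounds alone.

Three compounds share one core and differ only in the aryl group attached to the carbonyl carbon. Compound 1 `O=C(c1ccn(-c2ccc3c(c2)B(O)OC3)c1)c1ccc(Cl)cc1Cl` carries two chloro groups on that aryl ring. In an ADME assay on L929 cells (Mus musculus) for cytotoxicity, read by resazurin assay, with a stated time of 72 h (on this read-out higher numbers stand for weaker inhibition and lower numbers for stronger inhibition), compound 1 gives > 10 ug/mL, which is a limit of the assay and not a number. Compound 2 `O=C(c1ccc(Cl)cc1)c1ccn(-c2ccc3c(c2)B(O)OC3)c1` keeps a single chloro group on the same ring. In this assay compound 2 gives > 10 ug/mL, again a limit rather than a number. The step that the two limits leave unreadable from compound 1 to compound 2 therefore has no readable size, and both values sit at the limit of > 10 ug/mL in this assay, at which 2 of the 2 values shown sit.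

Compound 3 `Cc1cccc(C(=O)c2ccn(-c3ccc4c(c3)B(O)OC4)c2)c1` differs from compound 2 by 3-methylphenyl in place of 4-chlorophenyl on a carbonyl carbon. Among the measured compounds shown here, no measured step reports the size of a change of this kind, and the single step available, from compound 1 to compound 2, cannot be read. Compound 3 is therefore expected to remain at the same limit, with a step that the limit leaves unreadable from compound 2 to compound 3 that means no change beyond the scatter. The estimate for compound 3 is 20 ug/mL, between 8 ug/mL and 60 ug/mL, most likely reported only as a limit.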

Compound 3, half-maximal inhibitory concentration: > 10 ug/mL
Compound 3: only a limit was reported; the forecaster's own chance of this, stated with the estimate: 80%; the middle value lies beyond the limit too.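

Among the compounds shown here, with compound 3 also reported only as a limit, the steps among compound 1, compound 2 and compound 3 in this assay cannot be read, so this result gives no new step. All three values sit at one limit: the limit of > 10 ug/mL in this assay, at which 3 of the 3 values shown sit. The compounds shown leave open whether their aryl groups on the carbonyl carbon separate them at all in this assay.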